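Amine side-chain change from compound 3 to compound 4

The compounds below may be only part of what the source reports. "The series", "measured", "known", "first", "only" and "open" are said of these compounds alone.

In a functional assay on PC-3 cells (Homo sapiens) for antiproliferative activity, read by MTT assay, with a stated time of 72 h (a lower number here means a stronger inhibitor, a higher number a weaker inhibitor), compound 1 `O=C(N/N=C/c1ccc(Br)cc1)Nc1ccc(Oc2ccnc3[nH]ccc23)cc1` is reported as "not active" (no number reported). Compound 2 `O=C(N/N=C/c1cccc(Cl)c1Cl)Nc1ccc(Oc2ccnc3[nH]ccc23)cc1` is likewise reported as "not active" (no number reported). Going by the values given here, compound 3 `CCN(CC)CCn1cccc1/C=N/NC(=O)Nc1ccc(Oc2ccnc3[nH]ccc23)cc1` gives 1370 nM, the only number so far, so it has no numeric neighbour to be ranked against. Compound 4 `CN(C)CCCn1cccc1/C=N/NC(=O)Nc1ccc(Oc2ccnc3[nH]ccc23)cc1` differs from compound 3 in one place: (dimethylamino)methyl in place of diethylamino on a saturated chain carbon, two bonds along the chain from an aromatic nitrogen. Cut one bond further out, this reads 2-(diethylamino)ethyl to 3-(dimethylamino)propyl. Among the compounds with values here, no measured step is available for calibration, so no shift beyond the scatter is expected in this assay, in either direction. The expected step is a 1.1-fold higher number from compound 3 to compound 4 (0.04 log units; within the scatter). For compound 4 the estimated value is 1500 nM, with an expected range of 500 nM to 4500 nM.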

Compound 4, half-maximal inhibitory concentration: 5150 nM
Compound 4: middle estimate off by 3.4-fold (0.54 log units), on the low side, and the stated range ends below it.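

In this assay the amine side chain at this position affects the read-out: 3-(dimethylamino)propyl in place of 2-(diethylamino)ethyl gives a 3.8-fold higher number from compound 3 to compound 4 (0.58 log units; beyond the scatter) as a modest weakening beyond the scatter. Going by these compounds alone, this is the first measured step, and both amine-bearing compounds keep a numeric value. Nothing at hand gives a cause for this step.

Chain length and the groups on the amine change together here, so their separate contributions remain open. A 2-(dimethylamino)ethyl or 3-(diethylamino)propyl chain would separate them, and a morpholine ring in place of the open-chain amine remains an open question.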